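Replacing the aminoethyl amide in a pyrrole series

The compounds below may be only part of what the source reports. "The series", "measured", "known", "first", "only" and "open" are said of these compounds alone.

Among the measured compounds shown here, compound 1 `CCn1c(C(=O)NCCN)ccc1C(CC)(CC)c1ccc(OCCC(O)(CC)CC)c(C)c1` is the only member of this small set to give an actual number: in a functional assay on MCF7 cells (Homo sapiens) for antiproliferative activity, read by MTT assay, with a stated time of 48 h (a lower number here means a stronger inhibitor, a higher number a weaker inhibitor), compound 1 gives 670 nM. Compound 2 `C#CCCOC(=O)c1ccc(C(CC)(CC)c2ccc(OCCC(O)(CC)CC)c(C)c2)n1CC` reaches only the limit of the assay, > 50000 nM. Compound 3 `CCOc1ccc(NC(=O)c2ccc(C(CC)(CC)c3ccc(OCCC(O)(CC)CC)c(C)c3)n2CC)cc1` likewise reaches only the limit, > 50000 nM. Both changes to the amide end of compound 1 were costly: an at least 74-fold higher number from compound 1 to compound 2 (1.87 log units; beyond the scatter) and an at least 74-fold higher number from compound 1 to compound 3 (1.87 log units; beyond the scatter), so that the limit of > 50000 nM in this assay, at which 2 of the 3 values shown sit, is where two of three compounds sit.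

Compound 4 `CCOC(=O)C(CC(=O)OC)NC(=O)c1ccc(C(CC)(CC)c2ccc(OCCC(O)(CC)CC)c(C)c2)n1CC` changes the same end again: a group of 11 heavy atoms (7 carbon, 4 oxygen; no ring) in place of a group of 3 heavy atoms (2 carbon, 1 nitrogen; no ring), on an amide-type nitrogen. Since both earlier changes on that amide gave at least that large loss, a comparable rise is expected, a 60-fold higher number from compound 1 to compound 4 (1.78 log units; beyond the scatter). Compound 4 is therefore estimated at 40000 nM, within 5000 nM to 100000 nM, most likely reported only as a limit.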

Compound 4, half-maximal inhibitory concentration: 390 nM
Beside the measured number, compound 4's estimate is 100-fold (2.01 log units) above it, and the stated range ends above it.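

Compound 4 shows that the 2-aminoethyl group is not essential on this amide-type nitrogen in this assay: a much larger group without that amine fits the data equally well, with a 1.7-fold lower number from compound 1 to compound 4 (0.24 log units; within the scatter). Replacing 2-aminoethyl therefore does not always bring a large loss, as an at least 120-fold lower number from compound 3 to compound 4 (2.10 log units; beyond the scatter) and an at least 120-fold lower number from compound 2 to compound 4 (2.10 log units; beyond the scatter) show, and both of these steps start from an assay limit rather than a number.

Which part of the new group matters stays open. A carboxylic acid in that group, or a single methyl on the same nitrogen, would test this.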